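From pyrrolidin-1-yl to 2,3-dihydro-1H-indol-1-yl on a thiocarbonyl carbon

The source may report more compounds than this note shows. Statements on the series, on what has been measured and on what is new or still open speak of the compounds shown alone.

Of the compounds shown here, two sharing one core have been measured in a functional assay on MGC-803 cells (Homo sapiens) for inhibition, read by CCK-8 assay, with a stated time of 48 h; a higher number here means a weaker inhibitor, a lower number a stronger inhibitor. There, compound 1 `COc1ccc(CN(C(=O)CSc2nc3ccccc3o2)c2cc(OC)c(OC)c(OC)c2)cc1` gives 450 nM. Compound 2 `COc1ccc(CN(C(=O)CSC(=S)N2CCCC2)c2cc(OC)c(OC)c(OC)c2)cc1` gives > 20000 nM, which is a limit of the assay and not a number.

Compound 3 `COc1ccc(CN(C(=O)CSC(=S)N2CCc3ccccc32)c2cc(OC)c(OC)c(OC)c2)cc1` differs from compound 2 in one group: 2,3-dihydro-1H-indol-1-yl in place of pyrrolidin-1-yl on a thiocarbonyl carbon. The change puts a six-membered aromatic ring of carbon only on the thiocarbonyl carbon. Compound 2 has no such ring in that group, while the group on sulfur in compound 1 does have one, although compound 3 keeps the thiocarbonyl and so does not become compound 1.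

Among the compounds with values here, only one measured step bears on this, and it is large: an at least 44-fold higher number from compound 1 to compound 2 (1.64 log units; beyond the scatter). That step came with the loss of such a ring, so a move towards a lower number is expected, though one pair is thin support and only part of that step is expected to return. The step expected in this assay is an at least 5.0-fold lower number from compound 2 to compound 3 (0.69 log units; beyond the scatter). For compound 3 the estimated value is 4000 nM, with an expected range from 800 nM to 20000 nM.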

Compound 3, half-maximal inhibitory concentration: 8410 nM
Estimate against measurement, compound 3: 2.1-fold (0.32 log units) below; the range from low to high includes it.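

In this assay, going by these compounds, 2,3-dihydro-1H-indol-1-yl in place of pyrrolidin-1-yl on the thiocarbonyl carbon gives an at least 2.3-fold lower number from compound 2 to compound 3 (0.37 log units; beyond the scatter), so at this position a group with a six-membered aromatic ring of carbon only reads stronger than one without it, and the full size of the step stays unknown. The value of compound 2 is a limit of the assay and not a number: the limit of > 20000 nM in this assay, at which 1 of the 3 values shown sits. That ring alone does not bring back the earlier level, since exchanging the whole group on sulfur still leaves a 19-fold higher number from compound 1 to compound 3 (1.27 log units; beyond the scatter) in this assay, which shows that two groups each carrying such a ring are far from interchangeable here.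

The compounds shown leave open whether a chlorine atom or a methoxy group on the aromatic ring of 2,3-dihydro-1H-indol-1-yl would lower the number further, and whether a larger saturated amine such as piperidin-1-yl on the thiocarbonyl carbon would read differently from pyrrolidin-1-yl. They also cannot separate how much of the remaining gap belongs to the thiocarbonyl carbon and how much to the rest of the group on sulfur.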